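This account rests on a few compounds, and the source may have more. Where it says the series, first, only, none or still open, it means among the compounds named here.

Compound 2 `Cc1nc(C(NC(=O)C(=O)Nc2ccc(Cl)cc2)C2CCCCN2)sc1CO` stands among three compounds whose values in an ADME assay on MT2 cells (Homo sapiens) for cytotoxicity, read by XTT assay, with a stated time of 4 days (a lower number here means that less compound is tolerated, a higher number that more compound is tolerated), are all limits rather than numbers. In this assay compound 2 gives > 108000 nM, which is a limit and not a measured number. Compound 1 `Cc1nc(C(NC(=O)C(=O)Nc2ccc(F)c(F)c2)C2CCCCN2)sc1CO` gives > 87000 nM in this assay, again a limit. Compound 3 `Cc1nc(C(NC(=O)C(=O)Nc2ccc(C(F)(F)F)cc2)C2CCCCN2)sc1CO` gives > 75500 nM in this assay, also a limit. The steps among them, a step that the two limits leave unreadable from compound 1 to compound 2, a step that the two limits leave unreadable from compound 1 to compound 3 and a step that the two limits leave unreadable from compound 2 to compound 3, cannot be read because of the limit of > 108000 nM in this assay, at which 1 of the 3 values shown sits, the limit of > 75500 nM in this assay, at which 1 of the 3 values shown sits, and the limit of > 87000 nM in this assay, at which 1 of the 3 values shown sits, each hold one of the three values. Compound 4 `Cc1nc(C(NC(=O)C(=O)Nc2ccc(Cl)cc2)C2CCCN2)sc1CO` has not yet been measured; it differs from compound 2 in one place: pyrrolidin-2-yl in place of piperidin-2-yl on a saturated chain carbon bound to an amide-type nitrogen and an aromatic carbon. Among the compounds with values here, no measured step alters this part of the shared core, since the three steps change only the group on the amide-type nitrogen, and all three are unreadable. The estimate therefore means a step of an at least 1.0-fold lower number from compound 2 to compound 4 (0.03 log units; that floor lies within the scatter), expected to lie within the scatter. Compound 4 is expected to give 100000 nM in this assay, between 50000 nM and 200000 nM, most likely reported again as a limit.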

Compound 4, half-maximal cytotoxic concentration: 45000 nM
Estimate against measurement, compound 4: 2.2-fold (0.35 log units) above; measured number outside the range, below it.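

Pyrrolidin-2-yl in place of piperidin-2-yl gives the first readable step in this assay: an at least 2.4-fold lower number from compound 2 to compound 4 (0.38 log units; beyond the scatter). The earlier steps on the amide-type nitrogen cannot be read, so this saturated chain carbon is the first place shown where a change visibly alters how much compound is tolerated, and compound 4, at 45000 nM, is the only compound here with a number rather than a limit. The full size of the step remains unknown because the value for compound 2 is a limit: the limit of > 108000 nM in this assay, at which 1 of the 4 values shown sits.

From the compounds shown here alone, this position is covered by one pair only, with 4-chlorophenyl on the amide-type nitrogen, so it remains open whether the step holds with 3,4-difluorophenyl or 4-(trifluoromethyl)phenyl there. Going by these compounds, it is also open how an azetidin-2-yl ring or an open-chain amine at this place would compare.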